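The source may report more compounds than this note shows. Statements on the series, on what has been measured and on what is new or still open speak of the compounds shown alone.

Two compounds of a shared core were measured in an assay on tissue (HeLa cells) for inhibition of Indoleamine 2,3-dioxygenase 1 (Homo sapiens), read by spectrophotometry; on this read-out lower numbers stand for stronger inhibition and higher numbers for weaker inhibition. Compound 1 `OCc1cc2cc(/C(=N\O)Nc3cccc(Cl)c3)ccc2o1` gives 5900 nM in this assay. Compound 2 `COCc1cc2cc(/C(=N\O)Nc3cccc(F)c3)ccc2o1` gives 6100 nM in this assay, a number that sits within the scatter of compound 1. Compound 3 `COCc1cc2cc(/C(=N\O)Nc3cccc(Cl)c3)ccc2o1` carries chloro in place of fluoro on an aromatic carbon, that is, chloro in place of fluoro on an aromatic carbon. Among the measured compounds shown here, no step between measured compounds covers this change. The step expected from compound 2 to compound 3 in this assay is a 1.2-fold lower number from compound 2 to compound 3 (0.09 log units; within the scatter), small and not beyond the scatter. Compound 3 is therefore estimated at 5000 nM in this assay, with a range from 2500 nM to 12000 nM.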

Compound 3, half-maximal inhibitory concentration: 2200 nM
Estimate against measurement, compound 3: 2.3-fold (0.36 log units) above; measured number outside the range, below it.
By their numbers in this assay, from the lowest: compound 3; then compounds 1 and 2 (each within the scatter of the next).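

Chloro in place of fluoro on an aromatic carbon, meta to a large group, gives a 2.8-fold lower number from compound 2 to compound 3 (0.44 log units; beyond the scatter) in this assay, so the number responds to the halogen at this position. Methyl in place of hydrogen on an oxygen on a saturated carbon gives a 2.7-fold lower number from compound 1 to compound 3 (0.43 log units; beyond the scatter), so the number responds to that change as well. Nothing measured here accounts for either step.

Going by these compounds, what bromo or trifluoromethyl in place of chloro would give stays open. So does the outcome of an ethyl or a longer chain in place of the methyl on that oxygen.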